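Notes on substituent variation at the aromatic nitrogen

A few compounds are considered here, and "the series" means these few. Any claim that something is new, unique, unknown or untested is made for them only; others in the source may bear on it.

Measured compounds:
- compound 1 `COc1ccc([C@@H]2CC(=O)c3c(O)cc(OCc4cn(Cc5cccc(C#N)c5)nn4)cc3O2)cc1O`: 18000 nM
- compound 2 `COc1ccc([C@@H]2CC(=O)c3c(O)cc(OCc4cn(CC5CC5)nn4)cc3O2)cc1O`: 11900 nM
- compound 3 `COc1ccc([C@@H]2CC(=O)c3c(O)cc(OCc4cn(CCCO)nn4)cc3O2)cc1O`: 16700 nM

All three numbers come from a functional assay on RAW264.7 cells (Mus musculus) for inhibition, read by Griess assay, with stated times of 2 h and 24 h; on this read-out lower numbers stand for stronger inhibition and higher numbers for weaker inhibition. Compound 3 lies within the scatter of both others: a 1.1-fold lower number from compound 1 to compound 3 (0.03 log units; within the scatter) and a 1.4-fold higher number from compound 2 to compound 3 (0.15 log units; within the scatter), so the three numbers cannot be told apart. Compound 4 `COc1ccc([C@@H]2CC(=O)c3c(O)cc(OCc4cn(Cc5ccccc5C(F)(F)F)nn4)cc3O2)cc1O` carries 2-(trifluoromethyl)phenyl in place of 2-hydroxyethyl on a saturated chain carbon bound to an aromatic nitrogen. The step that bears most on this change is the reverse of a 1.1-fold lower number from compound 1 to compound 3 (0.03 log units; within the scatter), where a six-membered aromatic ring of carbon only on the saturated chain carbon gave the same result as the 2-hydroxyethyl group; a 1.5-fold lower number from compound 1 to compound 2 (0.18 log units; within the scatter) likewise left the number essentially unmoved. No step beyond the scatter is therefore expected in this assay. Compound 4 is expected to give about 16000 nM, with a range from 8000 nM to 32000 nM. The expected step is a 1.0-fold lower number from compound 3 to compound 4 (0.02 log units; within the scatter).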

Compound 4, half-maximal inhibitory concentration: 12500 nM
For compound 4 the middle estimate is 1.3-fold (0.11 log units) above the measured one; measured number inside the range.
By their numbers in this assay, from the lowest: compounds 2, 4, 3 and 1 (each within the scatter of the next).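

In this assay, 2-(trifluoromethyl)phenyl on the saturated chain carbon bound to an aromatic nitrogen stays within the scatter of all three earlier groups (a 1.3-fold lower number from compound 3 to compound 4 (0.13 log units; within the scatter); a 1.1-fold higher number from compound 2 to compound 4 (0.02 log units; within the scatter); a 1.4-fold lower number from compound 1 to compound 4 (0.16 log units; within the scatter)). A second substituted six-membered aromatic ring therefore adds no separation: the four compounds still cannot be told apart at this position. Nothing available explains this flat result.

From the compounds shown here alone, whether an amine or a carboxylic acid at this position would give a step beyond the scatter remains open, as does the effect of changes elsewhere on the shared core.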